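The compounds below may be only part of what the source reports. "The series", "measured", "known", "first", "only" and "open" are said of these compounds alone.

In a functional assay on HeLa cells (Homo sapiens) for cytotoxicity, read by MTT assay, with a stated time of 48 h (on this read-out higher numbers stand for weaker inhibition and lower numbers for stronger inhibition), compound 1 `CC1(C)CCC[C@]2(C)[C@@H](CC[C@@](C)(O)/C=C/c3cncc4ccccc34)[C@](C)(O)CC[C@@H]12` gives 46000 nM and compound 2 `CC(C)(C)c1ccc(/C=C/[C@](C)(O)CC[C@@H]2[C@@]3(C)CCCC(C)(C)[C@@H]3CC[C@@]2(C)O)cc1` gives 48500 nM on this read-out, so compound 2 stands within the scatter of compound 1. Compound 3 `COc1cccc(/C=C/[C@](C)(O)CC[C@@H]2[C@@]3(C)CCCC(C)(C)[C@@H]3CC[C@@]2(C)O)c1OC` carries 2,3-dimethoxyphenyl in place of 4-(tert-butyl)phenyl on a double-bonded chain carbon bound to a double-bonded chain carbon. Among the measured compounds shown here, the only measured step at this place (a 1.1-fold higher number from compound 1 to compound 2 (0.02 log units; within the scatter)) exchanged isoquinolin-4-yl for 4-(tert-butyl)phenyl and stayed within the scatter, so no step beyond the scatter is expected in this assay here. Compound 3 is expected at 45000 nM with an estimated range from 20000 nM to 100000 nM in this measurement. The estimate means an expected step (a 1.1-fold lower number from compound 2 to compound 3 (0.03 log units; within the scatter)) that stays small.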

Compound 3, half-maximal inhibitory concentration: 3880 nM
Beside the measured number, compound 3's estimate is 12-fold (1.06 log units) above it; measured number below the stated range.
By their numbers in this assay, from the lowest: compound 3; then compounds 1 and 2 (each within the scatter of the next).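

In this assay this place on the double-bonded chain carbon proves sensitive to the group it carries, which the earlier pair within the scatter did not show. Putting 2,3-dimethoxyphenyl there gives a 13-fold lower number from compound 2 to compound 3 (1.10 log units; beyond the scatter) and a 12-fold lower number from compound 1 to compound 3 (1.07 log units; beyond the scatter) with hydrogen-bond acceptors entering on the phenyl ring, though nothing given here accounts for the change.

The compounds shown leave open whether both methoxy groups are needed for the lower number. Nor do they show how a phenyl ring bearing a hydroxyl or an amine would read out here.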